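The source may report more compounds than this note shows. Statements on the series, on what has been measured and on what is new or still open speak of the compounds shown alone.

Of the compounds shown here, three with a shared core have been measured so far. In a functional assay on HepG2 cells (Homo sapiens) for cytotoxicity, read by sulforhodamine B assay, with a stated time of 24 h (a higher number here means a weaker inhibitor, a lower number a stronger inhibitor), compound 1 `N#CCC(=O)N/N=C1\C(=O)Nc2ccc(S(=O)(=O)N3CCOCC3)cc21` gives 7530 nM and compound 3 `COc1ccc(-c2c(C#N)c(N)n(/N=C3\C(=O)Nc4ccc(S(=O)(=O)N5CCOCC5)cc43)c(=O)c2C#N)cc1` gives 15000 nM on the same scale. Compound 2 `Cc1ccc(/N=C2\C(=O)Nc3ccc(S(=O)(=O)N4CCOCC4)cc32)cc1` gives 12800 nM in the same test, which lies within the usual scatter of both other values, so the numbers do not separate it from either one.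

Among the compounds with values here, compound 4 `CC(=O)N/N=C1\C(=O)Nc2ccc(S(=O)(=O)N3CCOCC3)cc21` has no measurement yet. It comes from compound 2 by a single change, acetamido in place of 4-methylphenyl on a double-bonded nitrogen, counted as acetamido in place of 4-methylphenyl on a double-bonded nitrogen in full.

Within the data shown here, only one measured step bears on this change, as it involves the same 4-methylphenyl at the same place. That step is a 1.7-fold higher number from compound 1 to compound 2 (0.23 log units; within the scatter) and puts 4-methylphenyl in place of ((cyanomethyl)carbonyl)amino, staying within the scatter. Acetamido and ((cyanomethyl)carbonyl)amino both carry a carbonyl on an amino group, so the expectation leans towards compound 1 at 7530 nM in this test. One step is thin evidence, but no step beyond the scatter is expected in this assay here. The estimated step is a 1.5-fold lower number from compound 2 to compound 4 (0.18 log units; within the scatter) and it points to a slightly lower number. Compound 4 is expected near 8500 nM with an estimated range from 3500 nM to 20000 nM in this test.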

Compound 4, half-maximal inhibitory concentration: 27500 nM
Beside the measured number, compound 4's estimate is 3.2-fold (0.51 log units) below it, outside the stated range (above it).
By their numbers in this assay, from the lowest: compounds 1, 2, 3 and 4 (each within the scatter of the next, the first and the last beyond it).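

In this assay, acetamido in place of 4-methylphenyl on a double-bonded nitrogen gives a 2.1-fold higher number from compound 2 to compound 4 (0.33 log units; beyond the scatter), so this place does respond to the group it carries, which the earlier step at the same place, staying within the scatter, could not show. Having a carbonyl on an amino group is also not enough to place a compound here: hydrogen in place of cyano on a saturated chain carbon bound to a carbonyl carbon gives a 3.7-fold higher number from compound 1 to compound 4 (0.56 log units; beyond the scatter), the largest step in this set, and it comes from that one small edit to the chain. Nothing in the data explains why the nitrile-bearing compound 1 and compound 4 differ.

As far as these compounds go, whether the lower number of compound 1 is special to the nitrile remains open, as an amine or a carboxylic acid on that same chain carbon would be needed to test it. Also open, from the compounds shown here alone, is how a longer chain on the carbonyl of acetamido would compare, which would show whether the number keeps moving as that chain grows.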